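An Ether Swapped for a Thioether in Compound 1

The source may report more compounds than this note shows. Statements on the series, on what has been measured and on what is new or still open speak of the compounds shown alone.

Among the compounds with values here, compound 1 `Nc1cc(N)c2nc(-c3ccccc3)c(Oc3ccc(Cl)c(Cl)c3)nc2c1` is the only compound with a plain number in a functional assay on HOP-62 cells (Homo sapiens) for inhibition, read by sulforhodamine B assay, with a stated time of 48 h; on this read-out lower numbers stand for stronger inhibition of growth and higher numbers for weaker inhibition of growth; in that assay compound 1 gives 38000 nM. Compound 2 `COc1cc(CNc2nc3cc(N)cc(N)c3nc2-c2ccccc2)cc(OC)c1OC` reaches only a limit of the assay, and in this assay compound 2 gives < 50200 nM. Within the data shown here, compound 1 therefore stands alone as a measured point, the one other value being a limit (the limit of < 50200 nM in this assay, at which 1 of the 2 values shown sits). Compound 3 `Nc1cc(N)c2nc(-c3ccccc3)c(Sc3ccc(Cl)c(Cl)c3)nc2c1` has not yet been measured in this assay. It differs from compound 1 in a single place ((3,4-dichlorophenyl)sulfanyl in place of 3,4-dichlorophenoxy on an aromatic carbon); the group that leaves and the group that enters share the same six-membered aromatic ring of carbon only and the same two chlorines, and both sit on an aromatic carbon next to the ring nitrogen and ortho to a phenyl group. Among the measured compounds shown here, with no measured pair of this kind to lean on, the account expects no shift in this assay beyond the usual scatter, in either direction. Compound 3 is thus estimated at 35000 nM, within 12000 nM to 100000 nM, a change described by a 1.1-fold lower number from compound 1 to compound 3 (0.04 log units; within the scatter) from compound 1.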

Compound 3, concentration for total growth inhibition: 77600 nM
The estimate for compound 3 lay 2.2-fold (0.35 log units) below the measured number; low and high end bracket the measured number.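

In this assay, replacing 3,4-dichlorophenoxy with (3,4-dichlorophenyl)sulfanyl on this aromatic carbon gives a 2.0-fold higher number from compound 1 to compound 3 (0.31 log units; beyond the scatter), a modest loss in growth inhibition. Within the data shown here, this shows that the position responds to the exchange of oxygen for sulfur in the linking atom, even though the two groups share the same aromatic ring, the same two chlorines and the same counts of heavy atoms, donors and acceptors, something that compound 1 alone, as the only plain number before, could not reveal. Nothing measured among these compounds accounts for the higher number with the sulfur-linked group.

Whether this step is specific to sulfur remains open, since the compounds shown do not tell how a sulfonyl link or a methylene link at the same position would compare with the oxygen and sulfur links. They also leave open whether the step would hold if a carboxylic acid replaced the two chlorines on the outer ring, or whether it depends on those chlorines being present.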